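Swapping the pyridine arm for a cyclohexyl ring

The compounds below may be only part of what the source reports. "The series", "measured", "known", "first", "only" and "open" are said of these compounds alone.

Measured so far:
compound 1, `C(=C/c1nn2c(-c3ccncc3)nnc2s1)\c1ccco1`: 82%
compound 2, `COc1ccccc1-c1nnc2sc(/C=C/c3ccco3)nn12`: 78%
compound 3, `c1ccc2c(Cc3nn4c(-c5ccoc5)nnc4s3)cccc2c1`: 77%

In an assay for inhibition of histone-lysine N-methyltransferase, H3 lysine-79 specific (Homo sapiens), read by scintillation counting, with stated times of 15 min and 60 min, tested at 100 uM, in the presence of a further agent that is not named here (on this read-out lower numbers stand for a weaker effect and higher numbers for a stronger effect at the one concentration tested), compound 1 gives 82%, the highest of the three numbers shown, yet the values of compound 2 and compound 3 sit within the usual scatter of it, so the three compounds cannot be ordered.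

Compound 4, `C(=C/c1nn2c(C3CCCCC3)nnc2s1)\c1ccco1`, has not been measured. It differs from compound 1 in one place: cyclohexyl in place of pyridin-4-yl on an aromatic carbon. For the measured compounds named here, no measured pair isolates such a change, so the effect is unknown. A moderate drop in this assay is expected, a number 14 percentage points lower from compound 1 to compound 4 (beyond the scatter), rather than a gain. Compound 4 is therefore estimated at 68%, with a range from 48% to 86%.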

Compound 4, a percentage reported as inhibition, at one concentration (the size of the read-out at that concentration, not a potency): 72%
Compound 4: the middle estimate sits 4 percentage points below what was measured, and the stated range covers the measured number.
By their numbers in this assay, from the lowest: compounds 4, 3, 2 and 1 (each within the scatter of the next).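

In this assay, cyclohexyl in place of pyridin-4-yl gives a number 10 percentage points lower from compound 1 to compound 4 (within the scatter) on this aromatic carbon. At this one concentration, then, the read-out does not separate an aromatic ring with a ring nitrogen from an all-carbon, non-aromatic ring of the same size here, so neither feature is shown to be needed. Nothing available explains this result.

Still open, as far as these compounds go, is how an open hexyl chain, or a cyclohexyl ring carrying an amine or a carboxylic acid, would read at this carbon. A single-concentration reading also leaves open whether compound 1 and compound 4 differ in potency.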